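The compounds below may be only part of what the source reports. "The series", "measured", "known", "first", "only" and "open" are said of these compounds alone.

Measured compounds:
- compound 1 `Cn1c(Cc2nn(C)c(=O)c3ccccc23)nnc1SCCCCCCCC(=O)Nc1ccc(F)cc1F`: "not determined" (no result reported)
- compound 2 `COc1ccc(NC(=O)CCCCCCCSc2nnc(Cc3nn(C)c(=O)c4ccccc34)n2C)cc1`: 26000 nM
- compound 3 `CC(C)COc1ccc(NC(=O)CCCCCCCSc2nnc(Cc3nn(C)c(=O)c4ccccc34)n2C)cc1`: 25000 nM

All three share one core, and each carries a different aromatic group on the amide nitrogen at the far end of the chain. Going by the values given here, in an assay on isolated protein for binding affinity to interleukin-15 (Homo sapiens), read by surface plasmon resonance (on this read-out lower numbers stand for tighter binding and higher numbers for weaker binding), compound 2 gives 26000 nM and compound 3 gives 25000 nM; the one step between them, a 1.0-fold lower number from compound 2 to compound 3 (0.02 log units; within the scatter), shows that swapping these two groups leaves the binding essentially unchanged. Compound 1 itself has no number in this assay, so its own place among these values is unknown.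

Compound 4 `Cc1ccc(NC(=O)CCCCCCCSc2nnc(Cc3nn(C)c(=O)c4ccccc34)n2C)c(Cl)c1` differs from compound 1 in one place: 2-chloro-4-methylphenyl in place of 2,4-difluorophenyl on an amide-type nitrogen. Among the compounds with values here, no measured step covers this particular exchange, and the only step that exists, from compound 2 to compound 3, concerns a different pair of groups at the same position and stays within the scatter. The two measured compounds sit close together, so the expectation is that compound 4 will also lie in that region, with no clear direction for any change. Compound 4 is therefore expected to give about 25000 nM, most likely between 8000 nM and 80000 nM.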

Compound 4, dissociation constant: 24100 nM
For compound 4 the middle estimate is 1.0-fold (0.02 log units) above the measured one; the range from low to high includes it.
By their numbers in this assay, from the lowest: compounds 4, 3 and 2 (each within the scatter of the next).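

In this assay, the earlier pair differed only in the chain on the oxygen of a 4-alkoxyphenyl group, whereas compound 4 brings a ring with a chlorine and a methyl and no oxygen at all. Even so, the numbers stay within the scatter (a 1.0-fold lower number from compound 3 to compound 4 (0.02 log units; within the scatter)) and (a 1.1-fold lower number from compound 2 to compound 4 (0.03 log units; within the scatter)), so among compound 2, compound 3 and compound 4 this broader exchange on the amide-type nitrogen leaves binding unchanged. No measurement shown here explains this flat result.

The compounds shown leave open whether a group of another kind at this place, such as a carboxylic acid, an amine or a pyridine ring in place of the phenyl, would shift the number at all. Going by these compounds, compound 1 has no number, so the effect of its 2,4-difluorophenyl group also remains unknown.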